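The source may hold more compounds than are shown below. What is called first, only, known or untested is meant among the compounds shown, and "the series" means these compounds.

In a functional assay on A549 cells (Homo sapiens) for cytotoxicity, read by sulforhodamine B assay, with a stated time of 96 h (a lower number here means that less compound is needed, a higher number that more compound is needed for the effect), compound 1 (`CCCC(=O)CC/C=C/C=C/C#CC#C/C=C/COC(C)=O`) gives 56400 nM, and compound 2 (`CCCC(=O)CC/C=C/C=C/C#CC#C/C=C/COC(=O)CCl`) gives 5100 nM, which is an 11-fold lower number from compound 1 to compound 2 (1.04 log units; beyond the scatter). Compound 3 (`CCCC(=O)CC/C=C/C=C/C#CC#C/C=C/C=O`) gives > 30000 nM, which is a limit and not a number. Compound 4 (`CCCC(=O)CC/C=C/C=C/C#CC#C/C=C/C(=O)O`) has hydroxy in place of hydrogen on a carbonyl carbon, turning formyl into carboxy: hydroxy in place of hydrogen on a carbonyl carbon. The closest guides are the steps that arrive at formyl, namely an at least 5.8-fold higher number from compound 2 to compound 3 (0.76 log units; beyond the scatter) and a step that the limit leaves unreadable from compound 1 to compound 3. Neither involves a carboxy group, so they offer only weak guidance, and no clear gain is expected. The expected change is a step that the limit leaves unreadable from compound 3 to compound 4, a small step that stays in the high range. Compound 4 is estimated at 40000 nM, with an expected range from 12000 nM to 100000 nM.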

Compound 4, half-maximal effective concentration: > 30000 nM
Compound 4 ended at the assay's limit (the forecaster's own chance of this, stated with the estimate: 55%); the middle value is on the limit's open side.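

In this assay compound 4 gives > 30000 nM, which is a limit of the assay and not a number. Carboxy in place of (((chloromethyl)carbonyl)oxy)methyl on the double-bonded chain carbon gives an at least 5.8-fold higher number from compound 2 to compound 4 (0.76 log units; beyond the scatter), so carboxy, like formyl, falls short of the chloro-bearing ester of compound 2. The steps to compound 4 from compound 3 and from compound 1 cannot be read: the limit of > 30000 nM in this assay, at which 2 of the 4 values shown sit.

As far as these compounds go, whether formyl and carboxy differ at all stays open. Also open, from the compounds shown here alone, is whether a methyl ester or a primary amide on that carbonyl carbon would give a readable number.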